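The compounds below may be only part of what the source reports. "The series", "measured", "known", "first", "only" and "open" are said of these compounds alone.

Measured in an in vitro ADME assay on microsomes from liver (Homo sapiens) for metabolic stability, using NADPH; a lower number here means slower removal, a higher number faster removal of the compound:
- Compound 1 `COc1ccc(OC(F)(F)F)cc1Cn1c(C(=O)NCC2(CO)CC2)cc2cc(C#N)ccc21`: 139 mL.min-1.g-1
- Compound 2 `COc1ccc(C(F)(F)F)cc1Cn1c(C(=O)NCC2(CO)CC2)cc2cc(C#N)ccc21`: 155 mL.min-1.g-1
- Compound 3 `COc1ccc(C(C)(C)C)cc1Cn1c(C(=O)NCC2(CO)CC2)cc2cc(C#N)ccc21`: 188 mL.min-1.g-1

Compound 2 cannot be separated from either of the other two measured compounds in this assay. The step to it is a 1.1-fold higher number from compound 1 to compound 2 (0.05 log units; within the scatter), and the step onward is a 1.2-fold higher number from compound 2 to compound 3 (0.08 log units; within the scatter). Even the widest step among the three, a 1.4-fold higher number from compound 1 to compound 3 (0.13 log units; within the scatter), stays within the scatter.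

The next compound, compound 4 `COc1ccc(C(F)(F)F)cc1Cn1c(C(=O)NCCC2(O)CCC2)cc2cc(C#N)ccc21`, differs from compound 2 elsewhere in the structure: (1-hydroxycyclobutyl)methyl in place of 1-(hydroxymethyl)cyclopropyl on a saturated chain carbon bound to an amide-type nitrogen. It carries (1-hydroxycyclobutyl)methyl in place of 1-(hydroxymethyl)cyclopropyl on a saturated chain carbon bound to an amide-type nitrogen.

Among the compounds with values here, none of the measured steps touches this place. All three exchange one group on an aromatic carbon for another, so they bear on the new change only indirectly. They show that the three compounds sharing this amide chain give closely similar numbers, but they say nothing about altering the chain itself. Within the data shown here, the data therefore give no direction for this step, and no shift beyond the scatter is expected. Compound 2, at 155 mL.min-1.g-1, remains the best anchor.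

The expected step is a 1.1-fold lower number from compound 2 to compound 4 (0.03 log units; within the scatter). For compound 4 the estimated value is 145 mL.min-1.g-1, with an expected range from 85 mL.min-1.g-1 to 230 mL.min-1.g-1.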

Compound 4, intrinsic clearance in microsomes: 88 mL.min-1.g-1
Compound 4: the middle estimate sits 1.6-fold (0.22 log units) above what was measured, within the range that was stated.
By their numbers in this assay, from the lowest: compounds 4, 1, 2 and 3 (each within the scatter of the next, the first and the last beyond it).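

Where the earlier compounds varied only a group on an aromatic carbon, compound 4 gives the one reading at the saturated chain carbon bound to an amide-type nitrogen, and in this assay the exchange of 1-(hydroxymethyl)cyclopropyl for (1-hydroxycyclobutyl)methyl gives a 1.8-fold lower number from compound 2 to compound 4 (0.25 log units; within the scatter), so this change cannot be separated from the scatter of the measurement. Within the data shown here, the single exchange replaces a three-membered ring of carbon with a four-membered one and also rearranges the chain that carries the hydroxyl group, so this pair cannot assign any part of the step to either feature. No measurement that could explain the step is available here.

The compounds shown leave open whether an amine or a carboxylic acid in place of the hydroxyl group, or a longer chain between the amide nitrogen and the ring, would give a step beyond the scatter. They also leave open how (1-hydroxycyclobutyl)methyl behaves with trifluoromethoxy or tert-butyl on the aromatic carbon, since this chain appears here only with trifluoromethyl.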